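A longer amide-tipped chain replaces the ethynyl end

The compounds below may be only part of what the source reports. "The series", "measured", "known", "first", "only" and "open" are said of these compounds alone.

Of the compounds shown here, three sharing one core have been measured in an assay on isolated protein for inhibition of leukotriene B4 receptor 1 (Homo sapiens), tested at 10 uM; a lower number here means less inhibition, a higher number more inhibition at the concentration tested (going by the name of the read-out). Compound 1 `C=CCc1cc(C(C)=O)c(O)cc1OCCCCCCCCC#N`, whose chain ends in a nitrile, gives 86%. Compound 2 `C=CCc1cc(C(C)=O)c(O)cc1OCCCCCCC`, with a plain chain, gives 31%. Compound 3 `C#CCCCCOc1cc(O)c(C(C)=O)cc1CC=C`, with a short chain ending in ethynyl, gives 74% and stands second highest of the three, behind compound 1 and well ahead of compound 2.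

Compound 4 `C=CCc1cc(C(C)=O)c(O)cc1OCCCCCC(=O)N(C)C` differs from compound 3 in one place: (dimethylcarbamoyl)methyl in place of ethynyl on a saturated chain carbon, four bonds along the chain from an oxygen on an aromatic ring. Within the data shown here, two measured steps touch this position. The change a number 43 percentage points higher from compound 2 to compound 3 (beyond the scatter) and the change a number 12 percentage points lower from compound 1 to compound 3 (beyond the scatter) together show that what sits at the end of this chain matters a great deal, with the nitrile-bearing chain of compound 1 highest and the plain chain of compound 2 lowest. The entering group brings back a hydrogen-bond acceptor at the chain end, much as the nitrile of compound 1 does, so a step in this assay of no size beyond the scatter is expected, a number 4 percentage points lower from compound 3 to compound 4 (within the scatter). Compound 4 is therefore estimated at 70%, in a range from 45% to 90%.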

Compound 4, a percentage reported as inhibition, at one concentration (the size of the read-out at that concentration, not a potency): 92%
Compound 4: the middle estimate sits 22 percentage points below what was measured; measured number outside the range, above it.
By their numbers in this assay, from the lowest: compound 2; then compound 3; then compounds 1 and 4 (each within the scatter of the next).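

In this assay, a chain ending in dimethylcarbamoyl does more than restore inhibition: replacing the ethynyl end gives a number 18 percentage points higher from compound 3 to compound 4 (beyond the scatter), and the comparison with the plain chain gives a number 61 percentage points higher from compound 2 to compound 4 (beyond the scatter). Against the nitrile-tipped chain the step is a number 6 percentage points higher from compound 1 to compound 4 (within the scatter), so these two different chain ends cannot be told apart here, and both stand clear of the ethynyl and plain ends. Nothing measured here accounts for these steps.

The compounds shown leave open how much of the rise from the ethynyl end belongs to the dimethylcarbamoyl group and how much to the longer chain that carries it. A dimethylcarbamoyl group on a shorter chain, or a primary amide or carboxylic acid on this same chain, would help separate the two.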